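The source may report more compounds than this note shows. Statements on the series, on what has been measured and on what is new or still open speak of the compounds shown alone.

The study concerns four compounds examined in a functional assay on Hs 683 cells (Homo sapiens) for cytotoxicity, read by MTT assay, with a stated time of 72 h; on this read-out lower numbers stand for stronger inhibition and higher numbers for weaker inhibition. Compound 1 `O=C1CC(c2c(-c3ccc[nH]3)[nH]c3ccccc23)C(=O)N1` gives 25000 nM in this assay, the lowest of the two numbers shown. Compound 3 `O=C1NC(=O)c2c1c1[nH]ncc1c1[nH]c3ccccc3c21` gives 93000 nM in this assay. The difference between the core of compound 1 and the core of compound 3 is not broken down here. Compound 2 `Cc1ccc2[nH]c3c4cn[nH]c4c4c(c3c2c1)C(=O)NC4=O` reaches only a limit of the assay, > 100000 nM, namely (the limit of > 100000 nM in this assay, at which 1 of the 3 values shown sits). The change from compound 3 to compound 2 is methyl in place of hydrogen on an aromatic carbon and brought an at least 1.0-fold higher number from compound 3 to compound 2 (0.03 log units; that floor lies within the scatter). Compound 4 `Cc1ccc2[nH]c(-c3ccc[nH]3)c(C3CC(=O)NC3=O)c2c1` carries the same kind of change relative to compound 1, (methyl in place of hydrogen on an aromatic carbon); here the ring is part of a fused or bridged system of two rings, whereas in compound 2 it is part of a fused or bridged system of five rings. Compound 4 is expected to give 30000 nM in this assay. The expected step is a 1.2-fold higher number from compound 1 to compound 4 (0.08 log units; within the scatter), and this expectation rests on the step of an at least 1.0-fold higher number from compound 3 to compound 2 (0.03 log units; that floor lies within the scatter). For compound 4 the estimated range runs from 12000 nM to 80000 nM.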

Compound 4, half-maximal inhibitory concentration: 8000 nM
The estimate for compound 4 lay 3.8-fold (0.57 log units) above the measured number; measured number below the stated range.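

In this assay, methyl in place of hydrogen on an aromatic carbon gave a 3.1-fold lower number from compound 1 to compound 4 (0.49 log units; beyond the scatter), a modest gain on the core of compound 1. The same change did not carry over from one core to the other with the same size: the same change on two cores in this assay, an at least 1.0-fold higher number (0.03 log units; that floor lies within the scatter) from compound 3 to compound 2 and a 3.1-fold lower number (0.49 log units; beyond the scatter) from compound 1 to compound 4, at least 3.3-fold (0.52 log units) apart, beyond the scatter of two such steps. Compound 2 gives > 100000 nM, which is a limit of the assay and not a number, so the step on that core is known only as a floor, and this single pair of cores does not show how the change would behave on any other core.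

Going by these compounds, it remains open whether an ethyl group, a methoxy group or an amine in the same place on the core of compound 1 would follow the methyl. On these data alone, the effect of a methyl elsewhere on that ring also remains open.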